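The compounds below may be only part of what the source reports. "The series", "measured", "known", "first", "only" and "open" are said of these compounds alone.

Measured so far in a functional assay on MCF7 cells (Homo sapiens) for cytotoxicity, read by MTT assay, with a stated time of 72 h; on this read-out higher numbers stand for weaker inhibition and lower numbers for stronger inhibition
compound 1 `COc1cccc(/C=C2\CCC/C(=C\c3ccccc3Br)C2=O)c1OC`: 9700 nM
compound 2 `COc1ccccc1/C=C1\CCC/C(=C\c2cccc(OC)c2OC)C1=O`: 12000 nM
compound 3 `COc1ccc(/C=C2\CCC/C(=C\c3cccc(OC)c3OC)C2=O)cc1`: 18600 nM

Compound 3 (18600 nM) lies within the scatter of both other compounds. Going to compound 4 `COc1cccc(/C=C2\CCC/C(=C\c3cccc(Cl)c3Cl)C2=O)c1OC` puts 2,3-dichlorophenyl in place of 4-methoxyphenyl on a double-bonded chain carbon bound to a double-bonded ring carbon.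

Within the data shown here, three measured steps bear on this change. Two exchange the group at that same place (a 1.9-fold higher number from compound 1 to compound 3 (0.28 log units; within the scatter)) and (a 1.6-fold higher number from compound 2 to compound 3 (0.19 log units; within the scatter)), and one puts methoxy in place of bromo on an aromatic carbon (a 1.2-fold higher number from compound 1 to compound 2 (0.09 log units; within the scatter)). All three stay within the scatter. Among the measured compounds shown here, no measured compound carries chlorine, so this evidence is indirect. For the measured compounds named here, compound 1 is the only measured compound with a halogen (9700 nM), and the estimate is placed near it. No step beyond the scatter is expected in this assay for this change (a 1.9-fold lower number from compound 3 to compound 4 (0.27 log units; within the scatter)). Compound 4 is estimated at 10000 nM (expected range 4000 nM to 25000 nM).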

Compound 4, half-maximal inhibitory concentration: > 20000 nM
Compound 4 was reported as a limit (the forecaster's own chance of this, stated with the estimate: 5%); middle value at least 2.0-fold (0.30 log units) away from the limit.
By their numbers in this assay, from the lowest: compounds 1, 2 and 3 (each within the scatter of the next). At a limit, above all of these: compound 4.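

In this assay, compound 4 is reported only as a limit, so each step to it gives a floor and not a size: the limit of > 20000 nM in this assay, at which 1 of the 4 values shown sits.

Among these compounds, at this place, on a double-bonded chain carbon bound to a double-bonded ring carbon, the exchange of 2-bromophenyl for 2,3-dichlorophenyl gives the first step beyond the scatter, an at least 2.0-fold higher number from compound 1 to compound 4 (0.31 log units; beyond the scatter), so carrying halogen on this aryl group does not by itself keep the number of compound 1. The floors of the other two steps, an at least 1.0-fold higher number from compound 3 to compound 4 (0.03 log units; that floor lies within the scatter) and an at least 1.6-fold higher number from compound 2 to compound 4 (0.22 log units; that floor lies within the scatter), lie within the scatter, so those two comparisons remain undecided.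

Where compound 4 truly lies past its limit remains open. Also open, going by these compounds, is what a single chlorine, an amine or a carboxylic acid on this phenyl ring would give in this assay.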